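This account rests on a few compounds, and the source may have more. Where it says the series, first, only, none or still open, it means among the compounds named here.

Working notes on the series. In a functional assay on BXPC-3 cells (Homo sapiens) for inhibition, read by MTT assay, with a stated time of 7 days (on this read-out lower numbers stand for stronger inhibition and higher numbers for weaker inhibition), compound 1 `O=C([C@@H]1CCCN(S(=O)(=O)c2ccc(S(=O)(=O)C3CCC3)cc2)C1)N1CCC(F)(F)CC1` gives 78 nM, the lowest of the three numbers recorded. Compound 2 `CCN(CC)S(=O)(=O)c1ccc(S(=O)(=O)N2CCC[C@@H](C(=O)N3CCS(=O)(=O)CC3)C2)cc1` gives 4430 nM and compound 3 `CCN(CC)S(=O)(=O)c1ccc(S(=O)(=O)N2CCC[C@@H](C(=O)N3CCOCC3)C2)cc1` gives 790 nM; the gap from compound 1 to compound 3 and the larger gap to compound 2 are both beyond the scatter. For the measured compounds named here, the only single-point step among the measured compounds is a 5.6-fold lower number from compound 2 to compound 3 (0.75 log units; beyond the scatter), and it sits on the carbonyl carbon, not on the sulfonyl sulfur.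

Compound 4 `CC(C)NS(=O)(=O)c1ccc(S(=O)(=O)N2CCC[C@@H](C(=O)N3CCC(F)(F)CC3)C2)cc1` differs from compound 1 by isopropylamino in place of cyclobutyl on a sulfonyl sulfur. Going by the values given here, no measured step touches this sulfonyl substituent, so the change is not directly anchored; compounds 2 and 3 carry a different sulfonyl substituent and also a different amide ring, so their values show only that this shared core tolerates variation there with weaker numbers. The expectation for compound 4 is therefore a modest step, a 2.3-fold higher number from compound 1 to compound 4 (0.36 log units; beyond the scatter), upward in this assay. Compound 4 is estimated at 180 nM, with a range from 50 nM to 650 nM.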

Compound 4, half-maximal inhibitory concentration: 470 nM
For compound 4 the middle estimate is 2.6-fold (0.42 log units) below the measured one, and the stated range covers the measured number.
By their numbers in this assay, from the lowest: compound 1; then compounds 4 and 3 (each within the scatter of the next); then compound 2.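

For the compounds shown here, the first measured step at the sulfonyl sulfur is in this assay: a 6.0-fold higher number from compound 1 to compound 4 (0.78 log units; beyond the scatter). This shows that the number responds to a change at this position, even though cyclobutyl and isopropylamino each hold 4 heavy atoms; the change opens the four-membered ring, brings in nitrogen and adds a hydrogen-bond donor, all in one step. No measurement is available to assign the step to any one of these differences.

The compounds shown leave open whether the ring or the nitrogen carries the step, a question that cyclobutylamino or plain isopropyl on the sulfonyl sulfur would address. Also open, as far as these compounds go, is whether a step of this size would hold with morpholin-4-yl in place of the difluorinated amide ring of compound 4.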